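This account rests on a few compounds, and the source may have more. Where it says the series, first, only, none or still open, it means among the compounds named here.

In a functional assay on KB cells (Homo sapiens) for cytotoxicity, read by MTT assay, with a stated time of 3 days (on this read-out higher numbers stand for weaker inhibition and lower numbers for stronger inhibition), compound 1 `N#Cc1c(O)nc(SCc2nc3ccccc3[nH]2)nc1-c1ccccc1` gives 6.2 nM, while compound 2 `N#Cc1c(Nc2nccs2)nc(SCc2nc3ccccc3[nH]2)nc1-c1ccccc1` gives 14.7 nM, the higher of the two numbers. Compound 3 `N#Cc1c(NNC(N)=S)nc(SCc2nc3ccccc3[nH]2)nc1-c1ccccc1` differs from compound 2 in one place, on a nitrogen on an aromatic ring: a group of 4 heavy atoms (1 carbon, 2 nitrogen, 1 sulfur; no ring) in place of a group of 5 heavy atoms (3 carbon, 1 nitrogen, 1 sulfur; one five-membered aromatic ring with 2 hetero atoms), on a nitrogen on an aromatic ring. Among the compounds with values here, the only measured step, a 2.4-fold higher number from compound 1 to compound 2 (0.37 log units; beyond the scatter), was modest and replaced hydroxy rather than the 1,3-thiazol-2-yl group, so it offers only a rough guide to size. A similarly small change is therefore expected, and the estimated step is a 1.3-fold lower number from compound 2 to compound 3 (0.13 log units; within the scatter). For compound 3 the expected value is 11 nM, with an estimated range of 4 nM to 35 nM.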

Compound 3, half-maximal inhibitory concentration: 3 nM
Estimate against measurement, compound 3: 3.7-fold (0.56 log units) above, and the stated range ends above it.
By their numbers in this assay, from the lowest: compound 3; then compound 1; then compound 2.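

Replacing the 1,3-thiazol-2-yl on this nitrogen with the ringless group gives a 4.9-fold lower number from compound 2 to compound 3 (0.69 log units; beyond the scatter), so a ring at this place is not needed for a low number. Set against hydroxy on the aromatic carbon, the ringless group with its attached nitrogen gives a 2.1-fold lower number from compound 1 to compound 3 (0.32 log units; beyond the scatter), which puts compound 3 lowest of the three, with both steps beyond the scatter. No measurement is available that explains either step.

Going by these compounds, whether the sulfur of the new group matters remains open, as the same chain with oxygen in its place would show. On these data alone, how a plain amine on that aromatic carbon would compare also remains open.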